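The compounds below may be only part of what the source reports. "The series", "measured", "known", "first", "only" and "open" are said of these compounds alone.

In an ADME assay on microsomes from liver (Rattus norvegicus) for metabolic stability, using NADPH, with a stated time of 10 min (a lower number here means that less of the compound is left, a higher number that more of the compound is left), compound 1 `NCCCCN(C[C@@H]1Cc2nccnc2CN1)[C@H]1CCCc2cccnc21` gives 67%. Compound 2 `NC(=O)NC/C=C\CN(C[C@H]1Cc2ncccc2CN1)[C@H]1CCCc2cccnc21` gives 1%, the lower of the two numbers and well beyond the usual scatter from compound 1. Compound 3 `CN(CCCCN(C[C@H]1Cc2ncccc2CN1)[C@H]1CCCc2cccnc21)C1CCOCC1` differs from compound 2 in one place: a group of 11 heavy atoms (9 carbon, 1 nitrogen, 1 oxygen; one six-membered non-aromatic ring with 1 hetero atom) in place of a group of 7 heavy atoms (4 carbon, 2 nitrogen, 1 oxygen; no ring), on a saturated chain carbon bound to an amine nitrogen. Within the data shown here, no measured pair shows this change on its own, so any prediction is uncertain. Compound 3 otherwise matches compound 2, so the expectation stays fairly close to the number of compound 2, which gives 1%. The expected change is a modest rise, a number 17 percentage points higher from compound 2 to compound 3 (beyond the scatter). For compound 3, the estimated value is 18%, with an expected range of 3% to 50%.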

Compound 3, percent of the compound remaining: 64%
The estimate for compound 3 lay 46 percentage points below the measured number; measured number above the stated range.
By their numbers in this assay, from the lowest: compound 2; then compounds 3 and 1 (each within the scatter of the next).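

In this assay, a group of 11 heavy atoms with one six-membered non-aromatic ring with 1 hetero atom replaces a group of 7 heavy atoms with no ring, on a saturated chain carbon bound to an amine nitrogen, and this gives a number 63 percentage points higher from compound 2 to compound 3 (beyond the scatter). Among these compounds, this single place can therefore strongly change how much compound remains, which the earlier compounds, differing in more than one place, could not show. No measurement here bears on the reason for this rise.
The compounds shown leave open whether a simple dimethylamine or a carboxylic acid at this place would give a similar number. They also leave open which part of the entering group matters.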